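A small exchange on a carbonyl carbon

A few compounds are considered here, and "the series" means these few. Any claim that something is new, unique, unknown or untested is made for them only; others in the source may bear on it.

Measured in a functional assay on A2780 cells (Homo sapiens) for antiproliferative activity, read by fluorescence, with a stated time of 72 h; a lower number here means a stronger inhibitor, a higher number a weaker inhibitor:
compound 1 `CN1CCC(C(=O)N2Cc3c(NC(=O)C4CC4)n[nH]c3C2(C)C)CC1`: 1420 nM
compound 2 `CC(C)(C)C(=O)N1Cc2c(NC(=O)c3cccnc3)n[nH]c2C1(C)C`: 690 nM
compound 3 `CN(C)CC(=O)Nc1n[nH]c2c1CN(C(=O)C(C)(C)C)C2(C)C`: 580 nM

Compound 1 gives 1420 nM, the highest number of the three and beyond the scatter from both of the others. Compound 2 and compound 3 lie within the scatter of each other. The next compound is compound 4 `CN1CCC(C(=O)N2Cc3c(NC(=O)c4ccc(F)c(F)c4)n[nH]c3C2(C)C)CC1`, which keeps the core of compound 1 and carries 3,4-difluorophenyl in place of cyclopropyl on a carbonyl carbon.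

Within the data shown here, only one measured step bears on this kind of exchange. It is a 1.2-fold lower number from compound 2 to compound 3 (0.08 log units; within the scatter), which puts (dimethylamino)methyl in place of pyridin-3-yl on a carbonyl carbon and stays within the scatter. That single step suggests that a change at this place need not move the number much. Compound 2, with pyridin-3-yl on that carbonyl carbon, gives 690 nM, but it also differs from compound 1 elsewhere, so its value gives only a weak hint towards a lower number. Among the measured compounds shown here, no measured compound carries 3,4-difluorophenyl.

The expected change is a small one towards a lower number, a 1.8-fold lower number from compound 1 to compound 4 (0.25 log units; within the scatter). For compound 4 the estimated value in this assay is 800 nM, with an expected range of 280 nM to 2300 nM.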

Compound 4, half-maximal inhibitory concentration: 100 nM
Compound 4: middle estimate off by 8.0-fold (0.90 log units), on the high side; the measured number lies below the stated range.
By their numbers in this assay, from the lowest: compound 4; then compounds 3 and 2 (each within the scatter of the next); then compound 1.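

In this assay, among these compounds, placing 3,4-difluorophenyl in place of cyclopropyl on a carbonyl carbon gives a 14-fold lower number from compound 1 to compound 4 (1.15 log units; beyond the scatter), so a change at this place can move the number by a large amount, which the only earlier step of this kind, a 1.2-fold lower number from compound 2 to compound 3 (0.08 log units; within the scatter), did not show. The large step comes with no hydrogen-bond donors, hydrogen-bond acceptors or net charge on either group; the listed differences are the three-membered non-aromatic ring giving way to a six-membered aromatic ring, the rise from 3 to 8 heavy atoms and the entry of 2 fluorine atoms. Among the compounds shown here, nothing available explains why this exchange moves the number so far.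

The compounds shown do not separate the contribution of the aromatic ring from that of the two fluorine atoms, since plain phenyl, which would divide the step, is not among them. They also leave open whether 3,4-difluorophenyl would give a similar step on the core of compound 2, and whether a saturated six-membered carbon ring such as cyclohexyl would behave more like cyclopropyl or like 3,4-difluorophenyl.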